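From phenyl to 4-fluorophenyl on a shared core

The compounds below may be only part of what the source reports. "The series", "measured", "known", "first", "only" and "open" are said of these compounds alone.

Compound 1 `COc1cc2ncnc(Nc3cc(O)[nH]n3)c2cc1OC`: < 100000 nM, a limit
Compound 2 `COc1cc2ncnc(Nc3cc(-c4ccccc4)[nH]n3)c2cc1OC`: < 100000 nM, a limit

In a functional assay on BT-20 cells (Homo sapiens) for cytotoxicity, read by MTT assay (a higher number here means a weaker inhibitor, a lower number a stronger inhibitor), compound 2 is known only through a limit, < 100000 nM. It therefore has no exact place on the scale. The two measured compounds share one bound: the limit of < 100000 nM in this assay, at which 2 of the 2 values shown sit. Within the data shown here, the only measured step is a step that the two limits leave unreadable from compound 1 to compound 2, with phenyl in place of hydroxy on an aromatic carbon. That step has no readable size, so it gives no guide to size or direction for the next change.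

Compound 3 `COc1cc2ncnc(Nc3cc(-c4ccc(F)cc4)[nH]n3)c2cc1OC` carries fluoro in place of hydrogen on an aromatic carbon, para to a large group: fluoro in place of hydrogen on an aromatic carbon. Among the measured compounds shown here, with no measured step to suggest otherwise, no shift beyond the scatter is expected in this assay. The expected step is a step that the limit leaves unreadable from compound 2 to compound 3. Compound 3 is estimated at 30000 nM, with an expected range from 6000 nM to 100000 nM.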

Compound 3, half-maximal inhibitory concentration: < 100000 nM
Compound 3: only a limit was reported; the forecaster's own chance of this, stated with the estimate: 40%; the middle value does not contradict the limit.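

In this assay compound 3 gives < 100000 nM as a limit and not an exact value. Among these compounds, no step among compound 1, compound 2 and compound 3 can be read: the limit of < 100000 nM in this assay, at which 3 of the 3 values shown sit. The compounds shown leave open how strongly each acts in this assay and whether hydroxy, phenyl or 4-fluorophenyl on the shared core makes any difference.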